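The compounds below may be only part of what the source reports. "The series", "measured", "known", "first", "only" and "open" are said of these compounds alone.

Compound 2 `Cc1ccc2oc(-c3ccc(NC(=O)CCl)cc3)nc2c1` stands second highest of the three numbers in a functional assay on MCF7 cells (Homo sapiens) for cytotoxicity, read by MTT assay, with a stated time of 24 h (on this read-out higher numbers stand for weaker inhibition and lower numbers for stronger inhibition), where compound 2 gives 4620 nM. Compound 3 `O=C(CCl)Nc1ccc(-c2nc3cc(F)ccc3o2)cc1` gives 3260 nM, a shift of a 1.4-fold lower number from compound 2 to compound 3 (0.15 log units; within the scatter). Compound 1 `CN(C)CCCN1CCN(CC(=O)Nc2ccc(-c3nc4cc(F)ccc4o3)cc2)CC1` gives 14800 nM, the widest gap from compound 2 in the set. Compound 4 `Cc1ccc2oc(-c3ccc(NC(=O)CCl)c(C)c3)nc2c1` has not yet been run in this assay; relative to compound 2 it carries methyl in place of hydrogen on an aromatic carbon. Among the compounds with values here, no measured pair shows this change: the only single-point step, a 1.4-fold lower number from compound 2 to compound 3 (0.15 log units; within the scatter), exchanges groups on the shared core and stays within the scatter, so it offers no direction. The expected step is therefore a 1.0-fold lower number from compound 2 to compound 4 (0.00 log units; within the scatter), nothing beyond the scatter. Compound 4 is estimated at 4600 nM, within a range of 2000 nM to 10500 nM.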

Compound 4, half-maximal inhibitory concentration: 96500 nM
Estimate against measurement, compound 4: 21-fold (1.32 log units) below, outside the stated range (above it).
By their numbers in this assay, from the lowest: compounds 3 and 2 (each within the scatter of the next); then compound 1; then compound 4.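

In this assay, the aromatic position ortho to the ((chloromethyl)carbonyl)amino group proves highly sensitive to substitution: adding methyl there gives a 21-fold higher number from compound 2 to compound 4 (1.32 log units; beyond the scatter). This step lies beyond the scatter, unlike the fluoro-for-methyl exchange, a 1.4-fold lower number from compound 2 to compound 3 (0.15 log units; within the scatter), so a change of a single heavy atom can matter greatly on this part of the series. Nothing available explains the size of this step.

Going by these compounds, whether a chloro, methoxy or amine group at this position gives a similar step remains open. So does whether methyl there has the same effect on compound 3.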